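Ester chain shortening in a dihydropyridine series

The compounds below may be only part of what the source reports. "The series", "measured", "known", "first", "only" and "open" are said of these compounds alone.

Measured so far in a functional assay, tested at 100 ug/mL; on this read-out lower numbers stand for a stronger effect and higher numbers for a weaker effect at the one concentration tested:
- compound 1, `CCOC(=O)C1=C(C)N(c2ccccc2)C=CC1c1ccccc1`: -13.8%
- compound 2, `CCOC(=O)C1=C(C)N(c2ccc(Br)cc2)C=CC1c1ccccc1`: -14.8%

Compound 1 carries the highest of the two numbers recorded in this assay, yet its nearest neighbour compound 2 sits a step of a number 1 percentage points lower from compound 1 to compound 2 (within the scatter) away, so the two cannot be placed in any order. Within the data shown here, that one step, a bromo in place of hydrogen on an aromatic carbon, is the only measured comparison and it shows no effect beyond the scatter.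

Compound 3, `COC(=O)C1=C(C)N(c2ccccc2)C=CC1c1ccccc1`, has not yet been run in this assay. Relative to compound 1 it differs by hydrogen in place of methyl on a saturated chain carbon bound to an oxygen next to a carbonyl group, which read one bond further out is ethyl to methyl, or ethoxycarbonyl to methoxycarbonyl. Among the measured compounds shown here, no measured step touches the ester chain, so nothing in the data bears directly on it; the only guidance is that the single change tried so far left the number within the scatter.

For compound 3 a step of a number 0.8 percentage points higher from compound 1 to compound 3 (within the scatter) is expected, that is, none beyond the scatter. Compound 3 is therefore estimated at -13%, with a range from -28% to 2%.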

Compound 3, a percentage reported as activity, at one concentration (the size of the read-out at that concentration, not a potency): -26.9%
The estimate for compound 3 lay 13.9 percentage points above the measured number; the range from low to high includes it.
By their numbers in this assay, from the lowest: compound 3; then compounds 2 and 1 (each within the scatter of the next).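

Among these compounds, the ester chain is the first place where one change moves the number beyond the scatter in this assay: ethoxycarbonyl to methoxycarbonyl gives a number 13.1 percentage points lower from compound 1 to compound 3 (beyond the scatter), whereas the bromo change on the aromatic ring gives only a number 1 percentage points lower from compound 1 to compound 2 (within the scatter). The read-out at this one concentration therefore responds to the ester chain, and removing a methyl from it shifts the number toward the stronger side, although this rests on a single pair and a modest step. Nothing at hand accounts for the size or direction of this step.

Still open, as far as these compounds go, is whether the number keeps following chain length, as a longer chain such as propoxycarbonyl could show, and whether a carboxylic acid or an amide in place of the ester keeps the lower number. Among the compounds shown here, also open is whether bromo stays without effect beyond the scatter when it is placed on the core of compound 3, since its only reading so far comes from the ethyl ester.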